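A few compounds are considered here, and "the series" means these few. Any claim that something is new, unique, unknown or untested is made for them only; others in the source may bear on it.

Measured so far in a physicochemical assay for lipophilicity, using the shake flask method; on this read-out lower numbers stand for lower lipophilicity and higher numbers for higher lipophilicity:
- compound 1 `C[C@H](Oc1ccc(NC(=O)CC(=O)O)c(C2CC2)c1)c1c(Cl)ccc(F)c1Cl` gives 1.9
- compound 2 `C[C@H](Oc1ccc2ncc(-c3ccn(CCC(=O)O)n3)c(C3CC3)c2c1)c1c(Cl)cccc1Cl` gives 2.7
- compound 3 `C[C@H](Oc1ccc2ncc(/C=C/S(=O)(=O)O)c(C3CC3)c2c1)c1c(Cl)ccc(F)c1Cl` gives 2.5

Compound 1 stands lowest of the three, with compound 3 and compound 2 both higher by more than the usual scatter. Compound 4 `C[C@H](Oc1cccc(C2CC2)c1)c1c(Cl)ccc(F)c1Cl` has not yet been measured. It differs from compound 1 by hydrogen in place of ((carboxymethyl)carbonyl)amino on an aromatic carbon. For the measured compounds named here, no two measured compounds differ in only one place, so no measured step can guide the estimate. The expectation rests on the size of this change and on the starting value of compound 1 (1.9). A large upward step in this assay is expected, estimated as a number 3.30 log units higher from compound 1 to compound 4 (beyond the scatter) and well beyond the scatter. Compound 4 is expected at 5.2 with an estimated range of 4.4 to 6 as its likely span.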

Compound 4, distribution coefficient: 5
The estimate for compound 4 lay 0.20 log units above the measured number; the measured number falls inside the stated range.
By their numbers in this assay, from the lowest: compound 1; then compounds 3 and 2 (each within the scatter of the next); then compound 4.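

In this assay, hydrogen in place of ((carboxymethyl)carbonyl)amino on the aromatic carbon ortho to a cyclopropyl group gives a number 3.10 log units higher from compound 1 to compound 4 (beyond the scatter), a large step. This is the first change in a single place among these compounds, and it shows that the read-out can move this far through this one position. Nothing shown here accounts for the size of the step. As far as these compounds go, whether a simple amine or a methoxy group on this carbon would fall nearer compound 1 or compound 4 remains open.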